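Carrying a Chlorophenyl Swap onto a Hydroxylated Core

The source may hold more compounds than are shown below. What is called first, only, known or untested is meant among the compounds shown, and "the series" means these compounds.

Compound 1 `Cc1ccc2[nH]c(-c3ccc(-c4ccc(-c5ccc(N(C)C)cc5)cc4)cc3)nc2c1` is measured in a functional assay on DWD cells (Homo sapiens) for inhibition, read by sulforhodamine B assay (on this read-out higher numbers stand for weaker inhibition of growth and lower numbers for stronger inhibition of growth), at 3230 nM. Compound 2 `Cc1ccc2[nH]c(-c3ccc(-c4ccc(-c5cccc(Cl)c5)cc4)cc3)nc2c1` differs from it by 3-chlorophenyl in place of 4-(dimethylamino)phenyl on an aromatic carbon; in this assay compound 2 gives 2510 nM, a step of a 1.3-fold lower number from compound 1 to compound 2 (0.11 log units; within the scatter). Compound 3 `CN(C)c1ccc(-c2ccc(-c3ccc(-c4nc5c(O)cccc5[nH]4)cc3)cc2)cc1` carries another core, differing from compound 1 by 4-hydroxy-1H-benzimidazol-2-yl in place of 5-methyl-1H-benzimidazol-2-yl on an aromatic carbon; in this assay compound 3 gives 9210 nM, a step of a 2.9-fold higher number from compound 1 to compound 3 (0.46 log units; beyond the scatter). Compound 4 `Oc1cccc2[nH]c(-c3ccc(-c4ccc(-c5cccc(Cl)c5)cc4)cc3)nc12` is not yet measured. It differs from compound 3 by 3-chlorophenyl in place of 4-(dimethylamino)phenyl on an aromatic carbon, the same change, at the same place, that separates compound 1 from compound 2. Because that change gave a 1.3-fold lower number from compound 1 to compound 2 (0.11 log units; within the scatter), an expected step of a 1.3-fold lower number from compound 3 to compound 4 (0.11 log units; within the scatter) follows. On this basis compound 4 is estimated at 7100 nM in this assay, with a likely range from 3200 nM to 16000 nM.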

Compound 4, concentration for 50% growth inhibition: 2100 nM
Compound 4: the middle estimate sits 3.4-fold (0.53 log units) above what was measured; measured number below the stated range.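

In this assay on the core of compound 3, 3-chlorophenyl in place of 4-(dimethylamino)phenyl brings a 4.4-fold lower number from compound 3 to compound 4 (0.64 log units; beyond the scatter) and so stronger inhibition of growth. The same change therefore has a different size on the two cores: the same change on two cores in this assay, a 1.3-fold lower number (0.11 log units; within the scatter) from compound 1 to compound 2 and a 4.4-fold lower number (0.64 log units; beyond the scatter) from compound 3 to compound 4, 3.4-fold (0.53 log units) apart, beyond the scatter of two such steps. This shows that a step seen on one core cannot simply be copied onto the other here, but two cores give no general rule, and these numbers do not tell why the steps differ.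

Still open, from the compounds shown here alone, is how this change would behave on a third core, such as one carrying a carboxylic acid or an amine. Also open, going by these compounds, is whether other groups at the same place would show the same dependence on the core.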